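Chloro in Place of Methoxy on a Shared Core

The source may report more compounds than this note shows. Statements on the series, on what has been measured and on what is new or still open speak of the compounds shown alone.

Three compounds on a shared core were tested in an assay on CHO cells for displacement of a labelled ligand from adenosine receptor A2b (Homo sapiens), read by scintillation counting, with a stated time of 75 min; a lower number here means a stronger inhibitor, a higher number a weaker inhibitor. Compound 1 `COc1cccc(/C=C/C(=O)Nc2nc3ccccc3c(=O)s2)c1` gives 679 nM. Compound 2 `COc1cccc(CCCC(=O)Nc2nc3ccccc3c(=O)s2)c1` gives 302 nM, and the difference between the two cores is not broken down here. Compound 3 `O=C(CCCc1cccc(Cl)c1)Nc1nc2ccccc2c(=O)s1` gives >= 1000 nM, which is a limit of the assay rather than a number. The change from compound 2 to compound 3 is chloro in place of methoxy on an aromatic carbon, and it produced an at least 3.3-fold higher number from compound 2 to compound 3 (0.51 log units; beyond the scatter). Compound 4 `O=C(/C=C/c1cccc(Cl)c1)Nc1nc2ccccc2c(=O)s1` carries the same change relative to compound 1, (chloro in place of methoxy on an aromatic carbon). Compound 4 is therefore expected to show a 3.7-fold higher number from compound 1 to compound 4 (0.57 log units; beyond the scatter) in this assay. That expectation rests on the earlier step of an at least 3.3-fold higher number from compound 2 to compound 3 (0.51 log units; beyond the scatter). The estimated value for compound 4 is 2500 nM, likely between 800 nM and 8000 nM. Because of the limit of >= 1000 nM in this assay, at which 1 of the 3 values shown sits, compound 4 may well be reported only as a limit.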

Compound 4, inhibition constant: > 1000 nM
Compound 4: no number, only a limit; the forecaster's own chance of this, stated with the estimate: 75%; the middle value does not contradict the limit.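

In this assay, compound 4 is reported only as a limit, > 1000 nM. Read against that limit, chloro in place of methoxy gives an at least 1.4-fold higher number from compound 1 to compound 4 (0.16 log units; that floor lies within the scatter), so this floor alone does not establish a loss on the core of compound 1. The result does not contradict the clearer step seen on the other core, but it does not show that the change has the same size on both: the same change on two cores in this assay, an at least 3.3-fold higher number (0.51 log units; beyond the scatter) from compound 2 to compound 3 and an at least 1.4-fold higher number (0.16 log units; that floor lies within the scatter) from compound 1 to compound 4; the limit leaves it open whether they differ

The compounds shown leave open how an amine, a hydroxyl or a fluoro group on the same aromatic carbon would read in this assay. Going by these compounds, it also remains open how the change from 3-methoxyphenyl to 3-chlorophenyl would read on a longer chain.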